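This account rests on a few compounds, and the source may have more. Where it says the series, first, only, none or still open, it means among the compounds named here.

Working notes on the series in a functional assay on HepG2 cells (Homo sapiens) for antiproliferative activity, read by CCK-8 assay, with a stated time of 72 h; a lower number here means a stronger inhibitor, a higher number a weaker inhibitor. Compound 1 `O=C(Nc1cccc(-c2oc3cc(-c4ccc(F)cc4)ccc3c(=O)c2O)c1)c1ccc(Br)cc1` gives 13900 nM. Compound 2 `COc1ccc(C(=O)Nc2cccc(-c3oc4cc(-c5ccc(F)cc5)ccc4c(=O)c3O)c2)c(F)c1` gives 45300 nM, and a 3.3-fold higher number from compound 1 to compound 2 (0.51 log units; beyond the scatter). For the measured compounds named here, on these two numbers compound 2 stands as the higher of the pair, with compound 1 the only neighbour.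

Compound 3 `O=C(Nc1cccc(-c2oc3cc(-c4ccc(F)cc4)ccc3c(=O)c2O)c1)c1ccc([N+](=O)[O-])cc1` is not yet measured. It differs from compound 2 by 4-nitrophenyl in place of 2-fluoro-4-methoxyphenyl on a carbonyl carbon. Going by the values given here, the one measured step that bears on this position is a 3.3-fold higher number from compound 1 to compound 2 (0.51 log units; beyond the scatter), which shows that a change of the aryl group on the carbonyl carbon moves the number by a modest but real amount. The entering 4-nitrophenyl shares with the 4-bromophenyl of compound 1 a single substituent on the ring, so compound 3 is expected to sit nearer compound 1 than compound 2, that is a 2.3-fold lower number from compound 2 to compound 3 (0.36 log units; beyond the scatter). The estimate for compound 3 in this assay is 20000 nM, with a range from 7000 nM to 60000 nM.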

Compound 3, half-maximal inhibitory concentration: 1860 nM
For compound 3 the middle estimate is 11-fold (1.03 log units) above the measured one, and the stated range ends above it.
By their numbers in this assay, from the lowest: compound 3; then compound 1; then compound 2.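

In this assay, for the compounds shown here, the aryl group on the carbonyl carbon turns out to be a far stronger lever than the earlier pair showed: the change gives a 24-fold lower number from compound 2 to compound 3 (1.39 log units; beyond the scatter), a large step, where the only earlier step at this position was modest. Nitro in place of bromo alone gives a 7.5-fold lower number from compound 1 to compound 3 (0.87 log units; beyond the scatter), so the identity of the single group on the phenyl ring matters, not just the presence of one, and compound 3 has the lowest number of the three. Nothing measured here explains this result.

Whether the lower number is specific to nitro remains open, as the compounds shown say nothing about a nitrile, an amine or a carboxylic acid on the same ring. The 2-fluoro and 4-methoxy groups of compound 2 also cannot be read separately.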